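Removing the methoxy group from an anticonvulsant thiadiazole series

The compounds below may be only part of what the source reports. "The series", "measured", "known", "first", "only" and "open" are said of these compounds alone.

Compound 1 `COc1ccc(Nc2nnc(Nc3nc(-c4ccc(Br)cc4)cs3)s2)cc1` gives 30 mg/kg in a functional assay on the whole organism (strain albino) with Mus musculus as the target, in the maximal electroshock model, with a stated time of 0.5 h; a lower number here means that less compound is needed, a higher number that more compound is needed for the effect. Compound 2 `Brc1ccc(-c2csc(Nc3nnc(Nc4ccccc4)s3)n2)cc1` differs by hydrogen in place of methoxy on an aromatic carbon and gives 300 mg/kg, a step of a 10-fold higher number from compound 1 to compound 2 (1.00 log units; beyond the scatter). Compound 3 `COc1ccc(Nc2nnc(Nc3nc(-c4ccccc4)cs3)s2)cc1` carries the other core, differing from compound 1 by hydrogen in place of bromo on an aromatic carbon; compound 3 gives 100 mg/kg, a step of a 3.3-fold higher number from compound 1 to compound 3 (0.52 log units; beyond the scatter). Compound 4 `c1ccc(Nc2nnc(Nc3nc(-c4ccccc4)cs3)s2)cc1` is not yet measured; it differs from compound 3 by hydrogen in place of methoxy on an aromatic carbon, the same change at the same place as that from compound 1 to compound 2, now made on the core of compound 3. For compound 4 a step of a 7.0-fold higher number from compound 3 to compound 4 (0.85 log units; beyond the scatter) is expected in this assay, because the earlier occurrence of this change gave a 10-fold higher number from compound 1 to compound 2 (1.00 log units; beyond the scatter). Compound 4 is therefore estimated at 700 mg/kg, between 250 mg/kg and 2000 mg/kg.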

Compound 4, minimum effective dose: 300 mg/kg
The estimate for compound 4 lay 2.3-fold (0.37 log units) above the measured number; low and high end bracket the measured number.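

On the core of compound 3, taking away the methoxy group again gives a higher number in this assay, with a 3.0-fold higher number from compound 3 to compound 4 (0.48 log units; beyond the scatter), so the direction of the change carried over but its size did not: the same change on two cores in this assay, a 10-fold higher number (1.00 log units; beyond the scatter) from compound 1 to compound 2 and a 3.0-fold higher number (0.48 log units; beyond the scatter) from compound 3 to compound 4, 3.3-fold (0.52 log units) apart, beyond the scatter of two such steps. Taking away the bromo group carried over less well, with no change at the digits printed from compound 2 to compound 4 (within the scatter), although the same change gave a step beyond the scatter where the methoxy group was present: the same change on two cores in this assay, a 3.3-fold higher number (0.52 log units; beyond the scatter) from compound 1 to compound 3 and no change at the digits printed (within the scatter) from compound 2 to compound 4, 3.3-fold (0.52 log units) apart, beyond the scatter of two such steps. The two groups therefore do not act independently across these four compounds, but the data do not show why, and two pairs cannot set a rule for other cores.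

The compounds shown leave open how other groups at these places, such as an amine, a chloro group or a longer alkoxy chain, would fare. On these data alone, whether their steps would also depend on the group at the other end of the molecule remains unknown.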